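A few compounds are considered here, and "the series" means these few. Any claim that something is new, unique, unknown or untested is made for them only; others in the source may bear on it.

In a functional assay on MCF7 cells (Homo sapiens) for inhibition, read by fluorescence, with a stated time of 72 h (on this read-out lower numbers stand for stronger inhibition of growth and higher numbers for weaker inhibition of growth), compound 1 (`CC(C)=CCn1cnc2c(Nc3cccc(Cl)c3)nc(N[C@H]3CC[C@H](N)CC3)nc21`) gives 4200 nM and compound 2 (`CCCCCCn1cnc2c(Nc3ccc(O)cc3)nc(N[C@H]3CC[C@H](N)CC3)nc21`) gives 3500 nM. These two values lie within the usual scatter of each other, so compound 1 cannot be ranked against compound 2, and both sit in the same low-micromolar range. Compound 3 (`CC(C)=CCC/C(C)=C/Cn1cnc2c(Nc3cccc(Cl)c3)nc(N[C@H]3CC[C@H](N)CC3)nc21`) has not yet been measured in this assay. It keeps the core of compound 1 and extends its chain, with 3-methylbut-2-en-1-yl in place of hydrogen on a saturated chain carbon bound to a double-bonded chain carbon. The chain that was 3-methylbut-2-en-1-yl thus becomes 3,7-dimethylocta-2,6-dien-1-yl. Among the measured compounds shown here, no two measured compounds differ in one place only, so nothing yet shows what a change of this kind does, and the only anchor is compound 1 at 4200 nM. A small shift toward stronger inhibition of growth is a cautious expectation, and it may not clear the scatter. The expected size of the change is a 1.9-fold lower number from compound 1 to compound 3 (0.28 log units; within the scatter). For compound 3, the estimated value is 2200 nM, with an expected range from 700 nM to 6500 nM.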

Compound 3, concentration for 50% growth inhibition: 3600 nM
The estimate for compound 3 lay 1.6-fold (0.21 log units) below the measured number; the measured number falls inside the stated range.
By their numbers in this assay, from the lowest: compounds 2, 3 and 1 (each within the scatter of the next).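

Among the compounds shown here, the first comparison in this assay of two compounds that differ in one place is the step of a 1.2-fold lower number from compound 1 to compound 3 (0.07 log units; within the scatter), and so it gives this position its first direct test. Adding 3-methylbut-2-en-1-yl on a saturated chain carbon bound to a double-bonded chain carbon brings in 5 more carbon atoms and turns the chain into 3,7-dimethylocta-2,6-dien-1-yl, yet the two compounds cannot be told apart in this read-out, so the larger chain is accepted here with no visible gain or loss in inhibition of growth. No accompanying measurement offers an explanation for this result.

One chain extension cannot show whether this position is insensitive to all changes, and a chain ending in an amine or a carboxylic acid, or a benzyl group, might give a different number from the chains seen so far. Compound 2 differs from compound 1 in more than one place, so it cannot help to separate the effect of the chain from that of the other changes.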